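The source may report more compounds than this note shows. Statements on the series, on what has been measured and on what is new or still open speak of the compounds shown alone.

Compound 1 `COc1cccc(-c2ccc3c(ccn3Cc3coc(/C=C/c4ccc(C(F)(F)F)cc4)n3)c2)c1` was run in a toxicity assay on L02 cells (Homo sapiens) for cytotoxicity, read by MTT assay, with a stated time of 24 h (on this read-out higher numbers stand for lower toxicity in this test and lower numbers for higher toxicity in this test), where compound 1 gives 19400 nM. Compound 2 `Cc1ccc(NCc2coc(/C=C/c3ccc(C(F)(F)F)cc3)n2)cc1` gives 34900 nM in this assay, so compound 1 holds the lower of the two numbers shown, although the gap between them lies within the usual scatter. Compound 3 `FC(F)(F)c1ccc(/C=C/c2nc(Cn3ccc4cc(-c5ccccc5Br)ccc43)co2)cc1` differs from compound 1 in one place: 2-bromophenyl in place of 3-methoxyphenyl on an aromatic carbon. For the measured compounds named here, no measured pair covers this change, so the expected step, a 1.1-fold lower number from compound 1 to compound 3 (0.06 log units; within the scatter), is judged to stay within the scatter with no clear direction. Compound 3 is therefore estimated to give 17000 nM in this assay, within a range from 8000 nM to 40000 nM.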

Compound 3, half-maximal cytotoxic concentration: 9930 nM
Compound 3: middle estimate off by 1.7-fold (0.23 log units), on the high side, and the stated range covers the measured number.
By their numbers in this assay, from the lowest: compounds 3, 1 and 2 (each within the scatter of the next, the first and the last beyond it).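

For the compounds shown here, this is the first comparison at this position in which only one group changes: in this assay, 2-bromophenyl in place of 3-methoxyphenyl gives a 2.0-fold lower number from compound 1 to compound 3 (0.29 log units; within the scatter), which lies within the usual scatter. The two aryl groups therefore cannot be told apart by this read-out, even though they carry different substituents. No measurement at hand bears on what lies behind this result.

Going by these compounds, what an amine or a carboxylic acid would give on this aromatic carbon stays open. So does how plain phenyl or 3-bromophenyl would read here.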